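A few compounds are considered here, and "the series" means these few. Any claim that something is new, unique, unknown or untested is made for them only; others in the source may bear on it.

Compound 3 `COc1ccc(C(=O)/C=C/c2cc(-c3cc(OC)c(OC)c(OC)c3)n[nH]2)cc1` gives -78% in a functional assay on MDA-MB-468 cells (Homo sapiens) for cytotoxicity, read by sulforhodamine B assay, with a stated time of 48 h, tested at 100 uM (on this read-out lower numbers stand for a stronger effect and higher numbers for a weaker effect at the one concentration tested), the lowest of the three numbers in the series. Compound 1 `COc1cc(-c2cc(/C=C/C(=O)c3ccc(N)cc3)[nH]n2)cc(OC)c1OC` gives -65% in this assay, and compound 2 `COc1cc(-c2cc(/C=C/C(=O)c3ccc(Cl)c(Cl)c3)[nH]n2)cc(OC)c1OC` gives -37% in this assay. Compound 4 `COc1cc(-c2cc(/C=C/C(=O)c3ccc(F)c(F)c3)[nH]n2)cc(OC)c1OC` differs from compound 3 by 3,4-difluorophenyl in place of 4-methoxyphenyl on a carbonyl carbon. The step that bears on this runs the other way: a number 41 percentage points lower from compound 2 to compound 3 (beyond the scatter), a large step. The step of a number 28 percentage points higher from compound 1 to compound 2 (beyond the scatter) is modest, and a number 13 percentage points lower from compound 1 to compound 3 (beyond the scatter) is modest. 3,4-difluorophenyl is not 3,4-dichlorophenyl, so only a partial reversal of the large step is expected. Compound 4 is expected to give -50% in this assay, between -75% and -20%. This estimate means an expected step of a number 28 percentage points higher from compound 3 to compound 4 (beyond the scatter), upward and beyond the scatter.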

Compound 4, a percentage reported as activity, at one concentration (the size of the read-out at that concentration, not a potency): -26%
Estimate against measurement, compound 4: 24 percentage points below; low and high end bracket the measured number.
By their numbers in this assay, from the lowest: compound 3; then compound 1; then compound 2; then compound 4.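

In this assay, 3,4-difluorophenyl on the carbonyl carbon gives the weakest effect of the four compounds: a number 52 percentage points higher from compound 3 to compound 4 (beyond the scatter) and a number 39 percentage points higher from compound 1 to compound 4 (beyond the scatter). Replacing 3,4-dichlorophenyl with this group does not restore the effect but weakens it further, with a number 11 percentage points higher from compound 2 to compound 4 (beyond the scatter). Both dihalogenated phenyl groups therefore fall on the weak side of 4-aminophenyl and 4-methoxyphenyl, with no exception among these compounds.

As far as these compounds go, it remains open whether a 4-fluorophenyl or a 4-ethoxyphenyl group would sit nearer the dihalogenated compounds or compound 3. The data shown offer no explanation for these steps.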